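The compounds below may be only part of what the source reports. "The series", "measured", "known", "first", "only" and "open" are said of these compounds alone.

Measured so far in a functional assay on HeLa cells (Homo sapiens) for cytotoxicity, read by CCK-8 assay, with a stated time of 14 h; a lower number here means a stronger inhibitor, a higher number a weaker inhibitor:
- compound 1 `CC(=O)OC[C@H]1O[C@@H](S[C@H]2CC(=O)[C@@H]3OC[C@H]2O3)[C@H](OC(C)=O)[C@@H](OC(C)=O)[C@@H]1OC(C)=O`: 91400 nM
- compound 2 `O=C(O)c1ccccc1S[C@H]1CC(=O)[C@@H]2OC[C@H]1O2`: 434000 nM

Compound 1 holds the lower of the two numbers, and the gap to compound 2 lies beyond the scatter. Compound 3 `CC(=O)OC[C@H]1O[C@@H](S[C@H]2CC(=O)[C@@H]3OC[C@H]2O3)[C@H](OC(C)=O)[C@@H](OC(C)=O)[C@H]1OC(C)=O` has the same atoms and bonds as compound 1: the two compounds have the same atoms and bonds and differ only in configuration as drawn: 1 of 8 stereo elements differ; a stereocentre at a saturated ring carbon is drawn R in compound 1 and S in compound 3. A stereocentre at a saturated ring carbon is drawn R in compound 1 and S in compound 3. Among the compounds with values here, no measured pair shows the effect of such a change, so the estimate is uncertain. The expected step in this assay stays within the scatter: a 1.1-fold higher number from compound 1 to compound 3 (0.04 log units; within the scatter). The estimated value for compound 3 is 100000 nM, with an expected range of 45000 nM to 230000 nM.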

Compound 3, half-maximal inhibitory concentration in the HeLa assay: 676000 nM
For compound 3 the middle estimate is 6.8-fold (0.83 log units) below the measured one; the whole stated range lies below it.
By their numbers in the HeLa assay, from the lowest: compound 1; then compounds 2 and 3 (each within the scatter of the next).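

In the HeLa assay compound 1 gives 91400 nM and compound 3 gives 676000 nM; a stereocentre at a saturated ring carbon, drawn R in compound 1 and S in compound 3, accounts for a 7.4-fold higher number from compound 1 to compound 3 (0.87 log units; beyond the scatter), so this position responds to configuration alone, which the earlier comparison of compound 1 with compound 2 could not show. In a physicochemical assay for lipophilicity (a higher number here means a more lipophilic compound, a lower number a more polar compound), compound 1 gives -1.13 and compound 3 gives -1.13, and the same change gives no change at the digits printed from compound 1 to compound 3 (within the scatter), so the partition coefficient does not follow the shift in this pair. The shift rests on a single change: the fact that compounds 1 and 3 differ only in the configuration as drawn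

Still open, as far as these compounds go, is whether the R drawing keeps its advantage with another group on this carbon, such as an amine or a free hydroxyl. From the compounds shown here alone, the other stereocentres of the core also remain open.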